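The compounds below may be only part of what the source reports. "The series", "measured", "known", "first", "only" and "open" are said of these compounds alone.

In a functional assay on HT-1080 cells (Homo sapiens) for cytotoxicity, read by MTT assay, with a stated time of 72 h (on this read-out higher numbers stand for weaker inhibition and lower numbers for stronger inhibition), compound 1 (`COc1ccc(/C=C2\CCC/C(=C\c3cccc(Cl)c3)C2=O)cc1OC`) gives 4900 nM, compound 2 (`COc1ccc(/C=C2\CCC/C(=C\c3ccccc3Br)C2=O)cc1OC`) gives 8400 nM and compound 3 (`COc1ccc(/C=C2\CCC/C(=C\c3cccc(Br)c3)C2=O)cc1OC`) gives 5200 nM. Compound 3 therefore stands within the scatter of both other compounds, and the three cannot be ranked. Compound 4 (`COc1ccc(/C=C2\CCC/C(=C\c3ccc(OC)c(OC)c3)C2=O)cc1`) has not yet been measured. Its change from compound 3 is 4-methoxyphenyl in place of 3-bromophenyl on a double-bonded chain carbon bound to a double-bonded ring carbon, so 4-methoxyphenyl takes the place of 3-bromophenyl.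

Among the compounds with values here, three measured steps bear on this place. Bromo in place of chloro gives a 1.1-fold higher number from compound 1 to compound 3 (0.03 log units; within the scatter), 3-bromophenyl in place of 2-bromophenyl gives a 1.6-fold lower number from compound 2 to compound 3 (0.21 log units; within the scatter), and 2-bromophenyl in place of 3-chlorophenyl gives a 1.7-fold higher number from compound 1 to compound 2 (0.23 log units; within the scatter). All three stay within the scatter, but none of them brings in 4-methoxyphenyl, so they offer only a loose guide. Taking compound 3 at 5200 nM as the starting point, no step beyond the scatter is expected in this assay. The estimated step is a 1.2-fold higher number from compound 3 to compound 4 (0.06 log units; within the scatter). For compound 4 the expected value is 6000 nM, with an estimated range from 2500 nM to 15000 nM.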

Compound 4, half-maximal inhibitory concentration: 7200 nM
Compound 4: middle estimate off by 1.2-fold (0.08 log units), on the low side; the measured number falls inside the stated range.
By their numbers in this assay, from the lowest: compounds 1, 3, 4 and 2 (each within the scatter of the next).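

In this assay, within the data shown here, 4-methoxyphenyl brings oxygen and a hydrogen-bond acceptor to this place, where the earlier compounds carried only a bromine or chlorine on the ring, and replacing 3-bromophenyl gives a 1.4-fold higher number from compound 3 to compound 4 (0.14 log units; within the scatter) in this comparison. Measured against the other two groups, the same change gives a 1.2-fold lower number from compound 2 to compound 4 (0.07 log units; within the scatter) and a 1.5-fold higher number from compound 1 to compound 4 (0.17 log units; within the scatter) in the same test. Across these four compounds, then, swapping a halogen-bearing ring for 4-methoxyphenyl on a double-bonded chain carbon bound to a double-bonded ring carbon produces no step beyond the scatter.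

Nothing measured here explains why these groups read alike. As far as these compounds go, whether an amine, a carboxylic acid or a longer chain at this place would shift the number beyond the scatter remains open.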